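Piperazine for piperidine on the benzyloxy benzamide series

The compounds below may be only part of what the source reports. "The series", "measured", "known", "first", "only" and "open" are said of these compounds alone.

Measured so far:
compound 1 `O=C(Nc1ccnnc1)c1cc(N2CCCCC2)ccc1OCc1ccccc1` gives 25.1 nM in an assay on Sf9 cells for inhibition of Leucine-rich repeat serine/threonine-protein kinase 2 (Homo sapiens), read by TR-FRET, with stated times of 30 min and 2 h; on this read-out lower numbers stand for stronger inhibition and higher numbers for weaker inhibition
compound 2 `O=C(Nc1cccc(F)c1)c1cc(C(F)(F)F)ccc1OCc1ccc(F)cc1` gives 31.6 nM
compound 3 `O=C(Nc1cccnc1)c1cc(C(F)(F)F)ccc1OCc1ccccc1` gives 12.6 nM

Compound 1 sits among three numbers that all lie within the usual scatter of one another: the gap to compound 2 is small, and the gap to compound 3, the widest of the set, still falls inside the scatter. The shared core across compound 1, compound 2 and compound 3 carries differing amide partners and differing substituents para to the benzyloxy group, yet the read-out barely moves.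

Compound 4 `CN1CCN(c2ccc(OCc3ccccc3)c(C(=O)Nc3ccnnc3)c2)CC1` has not been measured. It differs from compound 1 in one place: 4-methylpiperazin-1-yl in place of piperidin-1-yl on an aromatic carbon. Among the compounds with values here, no step between measured compounds covers this change. Nothing among the three measured compounds suggests a substituent at this position shifts the read-out much, so a step within the scatter is expected, with no clear direction.

The step of a 1.2-fold higher number from compound 1 to compound 4 (0.08 log units; within the scatter) is expected to stay within the scatter. Compound 4 is estimated at 30 nM, with a plausible range from 10 nM to 90 nM.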

Compound 4, half-maximal inhibitory concentration: 12.6 nM
Compound 4: the middle estimate sits 2.4-fold (0.38 log units) above what was measured; the range from low to high includes it.
By their numbers in this assay, from the lowest: compounds 3, 4, 1 and 2 (each within the scatter of the next, the first and the last beyond it).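

Within the data shown here, the pair gives the first direct reading at this position, and in this assay the step of a 2.0-fold lower number from compound 1 to compound 4 (0.30 log units; within the scatter) leaves the two compounds indistinguishable. On the aromatic carbon para to a benzyloxy group, 4-methylpiperazin-1-yl can therefore stand in place of piperidin-1-yl, bringing a second ring nitrogen and a methyl group, without the read-out moving beyond the scatter. No measurement in hand speaks to why the read-out responds in this way.

Going by these compounds, only these two rings have been compared at this position with the amide partner held constant, so the span of groups accommodated there remains open. A morpholin-4-yl ring, a piperazine bearing a longer chain on nitrogen in place of methyl, or an open-chain amine carrying a carboxylic acid would test how far this result extends.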